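This account rests on a few compounds, and the source may have more. Where it says the series, first, only, none or still open, it means among the compounds named here.

Measured so far in an assay for inhibition of Nitric oxide synthase, inducible (Homo sapiens), with a stated time of 30 min, tested at 1 mM; on this read-out higher numbers stand for more inhibition at the one concentration tested (going by the name of the read-out) and lower numbers for less inhibition:

Compound 1, `N=C(NCCC(O)c1ccccc1N)c1ccccc1`: 64.1%
Compound 2, `N=C(NCCC(O)c1ccccc1N)c1ccc(C(F)(F)F)cc1`: 60.5%

Compound 1 has the highest of the two numbers in this assay; its nearest neighbour is compound 2, and the step of a number 3.6 percentage points lower from compound 1 to compound 2 (within the scatter) lies within the scatter, so the two cannot be ordered. That step exchanges hydrogen for trifluoromethyl on an aromatic carbon of the benzamidine-bearing ring.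

Compound 3, `COc1ccc(N)c(C(O)CCNC(=N)c2ccccc2)c1`, is the next compound to be measured. It differs from compound 1 by methoxy in place of hydrogen on an aromatic carbon, the new group sitting on the amino-bearing ring, para to an amino group. For the measured compounds named here, no measured step touches this ring, and the one step that exists, a number 3.6 percentage points lower from compound 1 to compound 2 (within the scatter), is within the scatter and concerns a different group elsewhere. With nothing in the data pointing either way, the expected step of a number 2.1 percentage points lower from compound 1 to compound 3 (within the scatter) is none beyond the scatter. Compound 3 is therefore estimated at 62%, with a range from 47% to 77%.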

Compound 3, a percentage reported as inhibition, at one concentration (the size of the read-out at that concentration, not a potency): 95.9%
The estimate for compound 3 lay 33.9 percentage points below the measured number; measured number above the stated range.
By their numbers in this assay, from the lowest: compounds 2 and 1 (each within the scatter of the next); then compound 3.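

In this assay, this position on the amino-bearing ring responds strongly to a small change: methoxy in place of hydrogen, para to an amino group, gives a number 31.8 percentage points higher from compound 1 to compound 3 (beyond the scatter). The only earlier step, a number 3.6 percentage points lower from compound 1 to compound 2 (within the scatter), concerned a different place and showed no change that could be told from scatter, so this is the first change among these compounds to move the number clearly, and it does so with a group of 2 heavy atoms. Nothing measured here accounts for the rise.

On these data alone, it remains open whether the gain belongs to methoxy itself or would also appear with a hydroxy group, a chlorine atom or the longer ethoxy group on the same carbon. Equally open, as far as these compounds go, is whether methoxy on another carbon of this ring would give a similar number.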